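Ethoxy for methylsulfonyl on a shared bicyclic core

The source may report more compounds than this note shows. Statements on the series, on what has been measured and on what is new or still open speak of the compounds shown alone.

Within the data shown here, compound 2 `CS(=O)(=O)Cc1cccc2c1CCC2c1ncc[nH]1` stands at the higher of the two numbers measured so far, yet within the scatter of compound 1 `Clc1ccc2c(c1-c1cn[nH]c1)CCC2c1ncc[nH]1`: in a functional assay on CHO cells for agonist activity at Alpha-1A adrenergic receptor (Homo sapiens), read by fluorescence and calcium flux (a higher number here means that more compound is needed for the effect, a lower number that less compound is needed), compound 2 gives 84 nM, while compound 1 gives 78 nM. Compound 3 `CCOCc1cccc2c1CCC2c1ncc[nH]1` is obtained from compound 2 by the change (ethoxy in place of methylsulfonyl on a saturated chain carbon bound to an aromatic carbon). Among the measured compounds shown here, no measured pair shows the effect of such a change, so the step from compound 2 to compound 3 is expected to be a 1.2-fold higher number from compound 2 to compound 3 (0.08 log units; within the scatter), with no direction claimed beyond the scatter. Compound 3 is therefore estimated at 100 nM in this assay, within a range of 30 nM to 350 nM.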

Compound 3, half-maximal effective concentration: 62 nM
Compound 3: middle estimate off by 1.6-fold (0.21 log units), on the high side, within the range that was stated.
By their numbers in this assay, from the lowest: compounds 3, 1 and 2 (each within the scatter of the next).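

In this assay, ethoxy in place of methylsulfonyl on a saturated chain carbon bound to an aromatic carbon gives a 1.4-fold lower number from compound 2 to compound 3 (0.13 log units; within the scatter). This first pair read at this position shows that the sulfur-bearing group can give way to an ether without the values separating beyond the scatter. Nothing at hand explains this result. Going by these compounds, whether an amine, a carboxylic acid or a longer chain at this place would also stay within the scatter of compound 2 remains open. A single pair also cannot show whether this holds on other cores.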